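Anilino for hydroxy: working notes on compound 4

The source may hold more compounds than are shown below. What is called first, only, known or untested is meant among the compounds shown, and "the series" means these compounds.

compound 1 `O=C(O)CCCCC(CCSC(=O)c1ccccc1)SC(=O)c1ccccc1`: 81%
compound 2 `O=C(CCCCC1CCSS1)Nc1ccc([N+](=O)[O-])c(C(F)(F)F)c1`: 23.9%
compound 3 `O=C(CCCCC(S)CCS)Nc1ccc(Cl)cc1`: 25.5%

In a functional assay on Bel-7402 cells (Homo sapiens) for inhibition, read by MTT assay, with a stated time of 24 h, tested at 100 ug/mL (on this read-out higher numbers stand for more inhibition of growth at the one concentration tested and lower numbers for less inhibition of growth), compound 1 stands highest of the three, with compound 2 and compound 3 each lower by more than the scatter. The unmeasured compound 4 `O=C(CCCCC(CCSC(=O)c1ccccc1)SC(=O)c1ccccc1)Nc1ccccc1` keeps the core of compound 1 and carries anilino in place of hydroxy on a carbonyl carbon. Among the compounds with values here, no step between measured compounds isolates this change. Compound 2 at 23.9% and compound 3 at 25.5% also carry an amide on that carbonyl but differ from compound 1 elsewhere, so they give only indirect guidance. A fall beyond the scatter is expected in this assay, with a number 33 percentage points lower from compound 1 to compound 4 (beyond the scatter) as the estimated step. For compound 4 the estimated value is 48%, with an expected range of 22% to 78% for the measurement.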

Compound 4, percent growth inhibition at one concentration: "not active" (no number reported)
For compound 4 the study gives words and no number, and the estimate cannot be compared.
By their numbers in this assay, from the lowest: compounds 2 and 3 (each within the scatter of the next); then compound 1.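

In this assay, within the data shown here, compound 4 is reported in words only, as not active, so no step from compound 1 can be read. As far as these compounds go, the size of any change on going from hydroxy to anilino stays open. No available evidence bears on this result.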